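The source may hold more compounds than are shown below. What is called first, only, known or untested is meant among the compounds shown, and "the series" means these compounds.

Compound 3 `C[C@@H](OC(=O)Nc1c(-c2ccc(CC(=O)O)cc2)cnn1C)c1ccccc1` stands at the edge of what an in vitro functional assay on chem-1 cells for antagonist activity at lysophosphatidic acid receptor 3 (Homo sapiens), read by FLIPR and calcium flux, with stated times of 30 min and 100 s (a lower number here means a stronger inhibitor, a higher number a weaker inhibitor), can report: compound 3 gives > 30000 nM, a limit rather than a number. Compound 1 `CC(OC(=O)Nc1c(-c2ccc(F)cc2)cnn1C)c1ccccc1Cl` gives > 30000 nM, also a limit. Compound 2 `C[C@H](OC(=O)Nc1c(-c2ccccc2F)cnn1C)c1ccccc1Cl` gives > 30000 nM, again a limit. All three values sit at the limit of > 30000 nM in this assay, at which 3 of the 3 values shown sit. Compound 4 `C[C@@H](OC(=O)Nc1c(-c2ccc(-c3ccc(C4(C(=O)O)CC4)cc3)cc2)cnn1C)c1ccccc1` differs from compound 3 by 4-(1-carboxycyclopropyl)phenyl in place of carboxymethyl on an aromatic carbon. For the measured compounds named here, no measured pair shows what such a change does in this assay, and because compound 3 rests at a limit, only a move toward stronger inhibition could become visible. The expected step is an at least 6.0-fold lower number from compound 3 to compound 4 (0.77 log units; beyond the scatter), toward stronger inhibition, with much uncertainty. Compound 4 is therefore estimated at 5000 nM, with a range from 500 nM to 30000 nM.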

Compound 4, half-maximal inhibitory concentration: 8340 nM
Beside the measured number, compound 4's estimate is 1.7-fold (0.22 log units) below it, within the range that was stated.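

Replacing carboxymethyl with 4-(1-carboxycyclopropyl)phenyl on this aromatic carbon gives an at least 3.5-fold lower number from compound 3 to compound 4 (0.55 log units; beyond the scatter) in this assay. This position therefore accepts the larger group, and the change brings a measurable effect on inhibition. Compound 4 is the only compound shown with a real number rather than a limit: the limit of > 30000 nM in this assay, at which 3 of the 4 values shown sit.

For the compounds shown here, the single change adds both a phenyl ring and a cyclopropane ring, so the contribution of each stays unresolved. Going by these compounds, whether an amine or a longer chain at this position would give stronger inhibition also remains open.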